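A few compounds are considered here, and "the series" means these few. Any claim that something is new, unique, unknown or untested is made for them only; others in the source may bear on it.

Measured in a functional assay on HeLa cells (Homo sapiens) for antiproliferative activity, read by MTT assay, with a stated time of 48 h; a higher number here means a weaker inhibitor, a lower number a stronger inhibitor:
- compound 1 `COc1ccc2[nH]c(-c3cn(-c4ccccc4)nc3-c3ccccc3)nc2c1`: 2870 nM
- compound 2 `COc1ccc2[nH]c(-c3cn(-c4ccccc4)nc3-c3ccc(Cl)cc3)nc2c1`: 3630 nM
- compound 3 `COc1ccc(-c2nn(-c3ccccc3)cc2-c2nc3cc(Cl)ccc3[nH]2)cc1`: 1290 nM

Of these three, compound 3 has the lowest number (1290 nM) and stands apart from both others by more than the usual scatter. Compound 4 `COc1ccc(-c2nn(-c3ccccc3)cc2-c2nc3cc(OC)ccc3[nH]2)cc1` differs from it in one place: methoxy in place of chloro on an aromatic carbon. In short, methoxy takes the place of chloro on an aromatic carbon.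

For the measured compounds named here, no measured step makes this exact change. Going by the values given here, the only step available, a 1.3-fold higher number from compound 1 to compound 2 (0.10 log units; within the scatter), swaps hydrogen for chloro at a different place and stays within the scatter, so it offers little guidance. More telling, compound 1 (2870 nM) and compound 2 (3630 nM) already carry methoxy where compound 4 gains it, and both give higher numbers than compound 3. They also differ from compound 4 elsewhere, so the comparison is imperfect. A modest move towards weaker inhibition is therefore expected, with an estimated step of a 1.9-fold higher number from compound 3 to compound 4 (0.29 log units; within the scatter). For compound 4 the estimated value is 2500 nM, with an expected range of 1100 nM to 5500 nM.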

Compound 4, half-maximal inhibitory concentration: 1140 nM
Beside the measured number, compound 4's estimate is 2.2-fold (0.34 log units) above it, and the stated range covers the measured number.
By their numbers in this assay, from the lowest: compounds 4 and 3 (each within the scatter of the next); then compounds 1 and 2 (each within the scatter of the next).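

In this assay, for the compounds shown here, the swap at this position on the fused system of two rings gives a 1.1-fold lower number from compound 3 to compound 4 (0.05 log units; within the scatter) and so does not separate methoxy from chloro here, a direct comparison the earlier compounds did not offer. The two other steps to compound 4 involve a different aromatic carbon: methoxy in place of chloro gives a 3.2-fold lower number from compound 2 to compound 4 (0.50 log units; beyond the scatter) and methoxy in place of hydrogen gives a 2.5-fold lower number from compound 1 to compound 4 (0.40 log units; beyond the scatter) in this series. Among these four compounds, then, the changes that pass the scatter lie at that other place, while the change at this position does not.

Nothing available explains these results. On these data alone, it remains open whether an amine, a carboxylic acid or a longer chain such as ethoxy at this position would also leave the number within the scatter of compound 3.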